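This account rests on a few compounds, and the source may have more. Where it says the series, first, only, none or still open, it means among the compounds named here.

Compound 1 `CCN1C(=O)CN(C2CCCC2)c2nc(Nc3ccc(OC)cc3)ncc21`: > 30000 nM
Compound 2 `CC1CCN(c2ccc(Nc3ncc4c(n3)N(C3CCCC3)CC(=O)N4)nc2)CC1`: > 30000 nM
Compound 3 `CN1CCN(c2ccc(Nc3ncc4c(n3)N(C3CCCC3)CC(=O)N4C)cc2)CC1`: 10300 nM

In a functional assay on MDA-MB-231 cells (Homo sapiens) for inhibition, read by MTT assay, with a stated time of 48 h (a higher number here means a weaker inhibitor, a lower number a stronger inhibitor), compound 1 gives no number, only a limit, > 30000 nM. the limit of > 30000 nM in this assay, at which 2 of the 3 values shown sit, is where compound 1 stands. Compound 2 likewise gives only a limit, > 30000 nM. Compound 3 gives a measured value of 10300 nM.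

Compound 4 `CCN1C(=O)CN(C2CCCC2)c2nc(Nc3ccc(N4CCC(C)CC4)cc3)ncc21` differs from compound 1 by 4-methylpiperidin-1-yl in place of methoxy on an aromatic carbon. Among the compounds with values here, no measured pair covers this change, so its size is unknown. Compound 4 is expected to move toward stronger inhibition by an at least 2.0-fold lower number from compound 1 to compound 4 (0.30 log units; that floor lies within the scatter), since compound 3, which carries a saturated nitrogen ring on the same phenyl, gives 10300 nM. For compound 4 the estimate is 15000 nM, with a range from 5000 nM to 40000 nM.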

Compound 4, half-maximal inhibitory concentration: > 30000 nM
Compound 4 ended at the assay's limit; the forecaster's own chance of this, stated with the estimate: 40%; middle value at least 2.0-fold (0.30 log units) away from the limit.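

Compound 1 and compound 4 both give only a limit in this assay, not a number, and no step between them can be read: the limit of > 30000 nM in this assay, at which 3 of the 4 values shown sit.

As far as these compounds go, whether 4-methylpiperidin-1-yl in place of methoxy changes inhibition at all remains open.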